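Removing the Chloro Group from the Benzyl Ring

A few compounds are considered here, and "the series" means these few. Any claim that something is new, unique, unknown or untested is made for them only; others in the source may bear on it.

Going by the values given here, compound 2 `Cc1cc(S(=O)(=O)/N=C(\N)n2nccc2-c2ccccc2)c(SCc2cccc(Cl)c2)cc1Cl` gives 7000 nM in a functional assay on HCT-116 cells (Homo sapiens) for cytotoxicity, read by MTT assay, with a stated time of 72 h (a lower number here means a stronger inhibitor, a higher number a weaker inhibitor), the highest of the two numbers so far; its nearest neighbour is compound 1 `Cc1cccc(CSc2cc(Cl)c(C)cc2S(=O)(=O)/N=C(\N)n2nccc2-c2ccccc2)c1`, which gives 6500 nM. Compound 3 `Cc1cc(S(=O)(=O)/N=C(\N)n2nccc2-c2ccccc2)c(SCc2ccccc2)cc1Cl` differs from compound 2 by hydrogen in place of chloro on an aromatic carbon. Among the compounds with values here, the only measured step that bears on this position is a 1.1-fold higher number from compound 1 to compound 2 (0.03 log units; within the scatter), where swapping groups at the same place changed little. A step of no change at the digits printed from compound 2 to compound 3 (within the scatter) is therefore expected, with no shift beyond the scatter. Compound 3 is estimated at 7000 nM, within 3000 nM to 16000 nM.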

Compound 3, half-maximal inhibitory concentration: 12000 nM
Beside the measured number, compound 3's estimate is 1.7-fold (0.23 log units) below it, and the stated range covers the measured number.
By their numbers in this assay, from the lowest: compounds 1, 2 and 3 (each within the scatter of the next).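

Going from 3-chlorobenzyl to plain benzyl gives a 1.7-fold higher number from compound 2 to compound 3 (0.23 log units; within the scatter) in this assay, and losing the methyl group from the same place gives a 1.8-fold higher number from compound 1 to compound 3 (0.27 log units; within the scatter) on the same measure. Both steps stay within the scatter, so this position has now been seen empty as well as filled, and neither chloro nor methyl is shown to matter there. Nothing measured here offers an explanation for these numbers.

On these data alone, whether an amine, a carboxylic acid or a methoxy group at this place would move the number beyond the scatter remains open. So does the effect of a chloro group elsewhere on the benzyl ring.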